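Methyl for Bromo: What Compound 3 May Show

The compounds below may be only part of what the source reports. "The series", "measured", "known", "first", "only" and "open" are said of these compounds alone.

Measured compounds:
compound 1 `Nc1sc2cnccc2c1C(=O)c1ccc(Cl)cc1`: 0%
compound 2 `Nc1sc2cnccc2c1C(=O)c1ccc(Br)cc1`: 0%

In an assay on CHO cells for displacement of a labelled ligand from adenosine receptor A3 (Homo sapiens), tested at 10 uM (a higher number here means more inhibition at the concentration tested (going by the name of the read-out), a lower number less inhibition), compound 1 gives 0% and compound 2 gives 0%. Compound 2 stands level with compound 1, the step of no change at the digits printed from compound 1 to compound 2 (within the scatter) falling within the scatter. Compound 3 `Cc1ccc(C(=O)c2c(N)sc3cnccc23)cc1` differs from compound 2 by methyl in place of bromo on an aromatic carbon. Among the compounds with values here, no measured step covers methyl in place of bromo; the only step seen, bromo in place of chloro, showed no movement. Compound 3 is therefore expected to show no step beyond the scatter, a number 2 percentage points higher from compound 2 to compound 3 (within the scatter). Compound 3 is estimated at 2%, within -8% to 15%.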

Compound 3, a percentage reported as inhibition, at one concentration (the size of the read-out at that concentration, not a potency): 0%
Beside the measured number, compound 3's estimate is 2 percentage points above it; the measured number falls inside the stated range.
By their numbers in this assay, from the lowest: compounds 1, 2 and 3 (each within the scatter of the next).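

In this assay methyl in place of bromo gives no change at the digits printed from compound 2 to compound 3 (within the scatter) and methyl in place of chloro gives no change at the digits printed from compound 1 to compound 3 (within the scatter) at this place on the six-membered aromatic ring of carbon only. The flat result therefore now extends beyond the two halogens to an alkyl group, which compounds 1 and 2 alone could not show. Nothing measured here bears on why this is so. The compounds shown leave open whether an amine, a carboxylic acid or a longer chain at this place would move the number, and whether a change elsewhere on the shared core would.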